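The compounds below may be only part of what the source reports. "The series", "measured", "known", "first", "only" and "open" are said of these compounds alone.

Compound 1 `O=C(NO)c1ccc(-c2cn([C@H]3C[C@H](C(=O)O)N(CCCc4ccccc4)C3)nn2)cc1` carries a carboxy group on a saturated ring carbon of its core. In an assay on Sf9 cells for inhibition of histone deacetylase 11 (Homo sapiens), read by fluorescence, tested at 0.5 uM (a lower number here means less inhibition, a higher number more inhibition at the concentration tested (going by the name of the read-out)), compound 1 gives < 10%, which is a limit of the assay rather than a measured number. Compound 2 `O=C(NO)c1ccc(-c2cn([C@H]3C[C@H](CO)N(CCCc4ccccc4)C3)nn2)cc1` has hydroxymethyl in place of that carboxy group, and in this assay compound 2 gives 18%. Going by the values given here, the step of a number at least 8 percentage points higher from compound 1 to compound 2 (that floor lies within the scatter) is the only change here that reaches a readable number. Compound 3 `O=C(NO)c1cccc(-c2cn([C@H]3C[C@H](C(=O)O)N(CCCc4ccccc4)C3)nn2)c1` carries 3-(hydroxycarbamoyl)phenyl in place of 4-(hydroxycarbamoyl)phenyl on an aromatic carbon. In this assay compound 3 gives < 10%, again a limit. The step that the two limits leave unreadable from compound 1 to compound 3 therefore cannot be sized. Two of the three values sit at the limit of < 10% in this assay, at which 2 of the 3 values shown sit, so compound 1 stands at the floor of what this assay reports.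

Compound 4 `O=C(NO)c1ccc(-c2cn([C@H]3C[C@@H](C(=O)O)N(CCCc4ccccc4)C3)nn2)cc1` keeps every atom and bond of compound 1: the two compounds have the same atoms and bonds and differ only in configuration as drawn: 1 of 2 stereo elements differ; a stereocentre at a saturated ring carbon is drawn R in compound 1 and S in compound 4. Among the compounds with values here, none of the measured steps touches a stereocentre, so no measured step bears directly on this change; the only readable step came from swapping a group, not from turning one. With compound 1 at the limit, the expectation for compound 4 is no step beyond the scatter, that is a step that the limit leaves unreadable from compound 1 to compound 4. Compound 4 is estimated at 7%, with a range from 0% to 18%.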

Compound 4, a percentage reported as inhibition, at one concentration (the size of the read-out at that concentration, not a potency): 14%
Compound 4: the middle estimate sits 7 percentage points below what was measured, within the range that was stated.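

In this assay, turning the stereocentre at this saturated ring carbon, with the carboxy group kept and nothing else altered, gives a number at least 4 percentage points higher from compound 1 to compound 4 (that floor lies within the scatter). Compound 1 is reported only as a limit, so the true size of this step cannot be read, and a real difference between the two compounds is not established: the limit of < 10% in this assay, at which 2 of the 4 values shown sit. If the two compounds do differ in this assay, only the drawn configuration can be the reason, which makes this the first comparison shown that tests the spatial arrangement at this carbon rather than the group attached to it: the fact that compounds 1 and 4 differ only in the configuration as drawn

From the compounds shown here alone, it remains open whether the same turn of the stereocentre would matter with hydroxymethyl on this carbon, as in compound 2, or with 3-(hydroxycarbamoyl)phenyl on the aromatic carbon, as in compound 3, since each of these appears here in one configuration only. Also open, going by these compounds, is how an amine or a methyl ester on this ring carbon would read in this assay, in either configuration.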